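A few compounds are considered here, and "the series" means these few. Any claim that something is new, unique, unknown or untested is made for them only; others in the source may bear on it.

Measured so far in a functional assay on B16-F10 cells (Mus musculus) for cytotoxicity, read by MTT assay, with a stated time of 48 h; a lower number here means a stronger inhibitor, a higher number a weaker inhibitor:
Compound 1 `O=C(/C=C\Nc1cnc2ccccc2c1)c1nc(-c2ccc(C(F)(F)F)cc2)n2ccccc12`: in this assay compound 1 gives only a limit, > 30000 nM.
Compound 2 `O=C(/C=C\Nc1ccc(Cl)cc1)c1nc(-c2ccc(F)cc2)n2ccccc12`: in this assay compound 2 gives 11000 nM.
Compound 3 `O=C(/C=C\Nc1ccc2[nH]ccc2c1)c1nc(-c2ccc(C(F)(F)F)cc2)n2ccccc12`: in this assay compound 3 gives 18200 nM.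

Compound 3 holds the higher of the two numbers measured; the nearest is compound 2, and that gap lies within the scatter. The third value, that of compound 1, is a limit (the limit of > 30000 nM in this assay, at which 1 of the 3 values shown sits).

Compound 4 `O=C(/C=C\Nc1ccc(Cl)cc1)c1nc(-c2ccc(C(F)(F)F)cc2)n2ccccc12` is not yet measured. It differs from compound 3 in one place: 4-chlorophenyl in place of 1H-indol-5-yl on an amine nitrogen. Within the data shown here, one measured step touches the same amine nitrogen, an at least 1.6-fold lower number from compound 1 to compound 3 (0.21 log units; that floor lies within the scatter), and since it starts from a limit only its floor is known, and that floor is within the scatter. Compound 2 carries the 4-chlorophenyl that enters here, though it differs from compound 4 elsewhere; compound 2 gives 11000 nM, which sits within the scatter of the number for compound 3. Nothing here points to a shift beyond the scatter, so the expected step is a 1.4-fold lower number from compound 3 to compound 4 (0.15 log units; within the scatter). Compound 4 is estimated at 13000 nM, between 5000 nM and 30000 nM.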

Compound 4, half-maximal inhibitory concentration: > 30000 nM
Compound 4: no number, only a limit; the forecaster's own chance of this, stated with the estimate: 20%; middle value at least 2.3-fold (0.36 log units) away from the limit.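

Compound 4 gives only a limit in this assay, and it is the second compound shown to do so: the limit of > 30000 nM in this assay, at which 2 of the 4 values shown sit.

On the amine nitrogen, 4-chlorophenyl in place of 1H-indol-5-yl gives an at least 1.6-fold higher number from compound 3 to compound 4 (0.21 log units; that floor lies within the scatter) so this change is not firmly resolved, and its true size may be larger. The clearer information comes from the other aromatic substituent: with 4-chlorophenyl held on the amine nitrogen, trifluoromethyl in place of fluoro gives an at least 2.7-fold higher number from compound 2 to compound 4 (0.43 log units; beyond the scatter) and is the only step shown that is beyond the scatter.

The step joining compound 1 and compound 4 cannot be read, as both are limits. Still open, going by these compounds, is whether methyl, methoxy or a carboxylic acid in place of trifluoromethyl would give a measurable number with 4-chlorophenyl on the amine nitrogen.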